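CCR9 antagonists: swapping the heteroaryl ring on a sulfonamide core

The source may hold more compounds than are shown below. What is called first, only, known or untested is meant among the compounds shown, and "the series" means these compounds.

Measured so far:
compound 1 `CC(C)(C)c1ccc(S(=O)(=O)Nc2ccc(Cl)cc2-c2ncccc2N)cc1` gives 95 nM
compound 2 `CC(C)(C)c1ccc(S(=O)(=O)Nc2ccc(Cl)cc2-c2ncnc(CO)c2O)cc1` gives 11 nM

In a functional assay on isolated protein for antagonist activity at C-C chemokine receptor type 9 (Homo sapiens), read by calcium flux, with a stated time of 10 min (a higher number here means a weaker inhibitor, a lower number a stronger inhibitor), compound 2 stands lowest of the two measured numbers, with compound 1 the nearest at a higher number. The step of an 8.6-fold lower number from compound 1 to compound 2 (0.94 log units; beyond the scatter) shows that exchanging the aromatic ring on the shared core moves the read-out appreciably. Compound 3 `CCNc1nccnc1-c1cc(Cl)ccc1NS(=O)(=O)c1ccc(C(C)(C)C)cc1` is not yet measured; its change from compound 2 is a group of 9 heavy atoms (6 carbon, 3 nitrogen; one six-membered aromatic ring with 2 hetero atoms) in place of a group of 9 heavy atoms (5 carbon, 2 nitrogen, 2 oxygen; one six-membered aromatic ring with 2 hetero atoms), on an aromatic carbon. This step removes both oxygen-bearing groups and brings in an ethylamino-substituted ring, which makes compound 3 resemble compound 1, with its amino-bearing ring, more than compound 2. Because compound 1 sits at 95 nM and compound 2 at 11 nM, a number between the two is expected for compound 3, most likely a modest rise over compound 2, estimated as a 3.6-fold higher number from compound 2 to compound 3 (0.56 log units; beyond the scatter). The estimate for compound 3 is 40 nM, in a range of 12 nM to 130 nM.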

Compound 3, half-maximal inhibitory concentration: 421 nM
Beside the measured number, compound 3's estimate is 11-fold (1.02 log units) below it; the measured number lies above the stated range.
By their numbers in this assay, from the lowest: compound 2; then compound 1; then compound 3.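

The step of a 38-fold higher number from compound 2 to compound 3 (1.58 log units; beyond the scatter) shows that at this aromatic carbon, two groups with the same count of heavy atoms, each built on a six-membered aromatic ring with 2 hetero atoms, can give very different numbers. Heavy-atom count and ring type therefore do not settle the result here, and the step of a 4.4-fold higher number from compound 1 to compound 3 (0.65 log units; beyond the scatter) shows that carrying a nitrogen substituent does not keep compound 3 level with compound 1 either. Nothing measured here explains either shift.

On these data alone, in the step to compound 3, the two oxygen-bearing groups leave and the ethylamino group enters together, so their separate contributions remain unknown. Rings carrying only the hydroxyl group, only the hydroxymethyl group, or a plain amine in place of ethylamino would be needed to pull these changes apart.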